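A few compounds are considered here, and "the series" means these few. Any claim that something is new, unique, unknown or untested is made for them only; others in the source may bear on it.

Working notes on the series. Compound 1 `Cc1ccc(Nc2ncc(C(F)(F)F)c(N3Cc4cccc(N(C)S(C)(=O)=O)c4C3)n2)c(Cl)c1` in a functional assay on HeLa cells (Homo sapiens) for antiproliferative activity, read by spectrophotometry, with a stated time of 2 days (on this read-out lower numbers stand for stronger inhibition of growth and higher numbers for weaker inhibition of growth), gives 10900 nM, the second highest of the three numbers in hand. Compound 2 `Cc1cc(Cl)ccc1Nc1ncc(C(F)(F)F)c(N2Cc3cccc(N(C)S(C)(=O)=O)c3C2)n1` in this assay gives 17400 nM, and the step of a 1.6-fold higher number from compound 1 to compound 2 (0.20 log units; within the scatter) is one to set aside. Compound 3 `COc1cc(Nc2ncc(C(F)(F)F)c(N3Cc4cccc(N(C)S(C)(=O)=O)c4C3)n2)cc(C(F)(F)F)c1` in this assay gives 5100 nM; it is reached by a 2.1-fold lower number from compound 1 to compound 3 (0.33 log units; beyond the scatter) and by a 3.4-fold lower number from compound 2 to compound 3 (0.53 log units; beyond the scatter), both modest lowerings that clear the scatter.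

Compound 4 `CN(c1cccc2c1CN(c1nc(Nc3cc(Cl)cc(C(F)(F)F)c3)ncc1C(F)(F)F)C2)S(C)(=O)=O` is still to be measured. Against compound 1 the change is 3-chloro-5-(trifluoromethyl)phenyl in place of 2-chloro-4-methylphenyl on a nitrogen on an aromatic ring. The entering group shares its trifluoromethyl with the 3-methoxy-5-(trifluoromethyl)phenyl of compound 3, and the two steps into compound 3 are the ones that bear on it. Because of a 2.1-fold lower number from compound 1 to compound 3 (0.33 log units; beyond the scatter) a modest lowering of the number is expected for compound 4, of about a 2.0-fold lower number from compound 1 to compound 4 (0.30 log units; within the scatter). Compound 4 is therefore expected to give 5500 nM in this assay, within a range of 2500 nM to 12000 nM.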

Compound 4, concentration for 50% growth inhibition: 4300 nM
Estimate against measurement, compound 4: 1.3-fold (0.11 log units) above; measured number inside the range.
By their numbers in this assay, from the lowest: compounds 4 and 3 (each within the scatter of the next); then compounds 1 and 2 (each within the scatter of the next).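

Chloro in place of methoxy on an aromatic carbon gives a 1.2-fold lower number from compound 3 to compound 4 (0.07 log units; within the scatter), so this single change does not separate the two groups in this series. The 3-chloro-5-(trifluoromethyl)phenyl group also clears the scatter against both aryl groups without trifluoromethyl, with a 2.5-fold lower number from compound 1 to compound 4 (0.40 log units; beyond the scatter) and a 4.0-fold lower number from compound 2 to compound 4 (0.61 log units; beyond the scatter). A second group carrying trifluoromethyl therefore gives lower numbers than the 2-chloro-4-methylphenyl and 4-chloro-2-methylphenyl groups, and neither compound 3 nor compound 4 goes against this among the four compounds.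

No measurement shown gives a reason for these steps. From the compounds shown here alone, it remains open whether trifluoromethyl alone accounts for the lowering, and whether a nitrile or a carboxylic acid in place of the chloro of compound 4 would hold the number.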